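The compounds below may be only part of what the source reports. "The series", "measured", "known", "first", "only" and "open" are said of these compounds alone.

In a functional assay on PC-3 cells (Homo sapiens) for cytotoxicity, read by colorimetric assay (a lower number here means a stronger inhibitor, a higher number a weaker inhibitor), compound 1 (`O=C(/C=C/c1ccc(CN2C(=O)/C(=C3\Nc4ccccc4\C3=N/O)c3cccc(Cl)c32)cc1)NO`) gives 90 nM, and compound 2 (`O=C(NO)c1ccc(CN2C(=O)/C(=C3\Nc4ccccc4\C3=N/O)c3cc(Cl)ccc32)cc1`) gives 50 nM. Within the data shown here, these two values lie within the usual scatter of each other, so compound 1 stands level with the only other measured compound, and no ranking can be drawn between them. Compound 3 (`O=C(NO)c1ccc(CN2C(=O)/C(=C3\Nc4ccccc4\C3=N/O)c3cccc(Cl)c32)cc1`) has not yet been measured. It is compound 1 with a single change: hydroxycarbamoyl in place of 2-(hydroxycarbamoyl)ethenyl on an aromatic carbon, with hydroxycarbamoyl in place of 2-(hydroxycarbamoyl)ethenyl on an aromatic carbon. Among the measured compounds shown here, no measured pair shows what this swap does in this assay, so the expectation rests on the two values alone, which sit close together. A small move towards a lower number is expected, with nothing beyond the scatter. The estimated change is a 1.4-fold lower number from compound 1 to compound 3 (0.14 log units; within the scatter). For compound 3 the expected value is about 65 nM, with an estimated range from 25 nM to 180 nM.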

Compound 3, half-maximal inhibitory concentration: 60 nM
Compound 3: middle estimate off by 1.1-fold (0.03 log units), on the high side; the range from low to high includes it.
By their numbers in this assay, from the lowest: compounds 2, 3 and 1 (each within the scatter of the next).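

Swapping the 2-(hydroxycarbamoyl)ethenyl group for hydroxycarbamoyl, on an aromatic carbon para to a large group, gives the first direct reading of this change in this assay: a 1.5-fold lower number from compound 1 to compound 3 (0.18 log units; within the scatter). With the rest of the molecule the same, a group of 4 heavy atoms can therefore stand in place of one of 6 at this position without a difference that can be told from the scatter of the assay. No separate measurement bears on why the two groups read alike.

From the compounds shown here alone, whether this position would also accept a carboxylic acid or an amine in place of hydroxycarbamoyl remains open, as does what a longer chain ending in hydroxycarbamoyl would do. This single step also cannot show whether the same swap would read alike on a different core.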